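This account rests on a few compounds, and the source may have more. Where it says the series, first, only, none or still open, it means among the compounds named here.

Measured compounds:
Compound 1 `CCCc1nnc(SCC(=O)c2ccc(Cl)cc2)n1N1C(=O)c2ccccc2C1=O` — in a functional assay on HepG2 cells (Homo sapiens) for cytotoxicity, read by MTT assay, with a stated time of 48 h (a higher number here means a weaker inhibitor, a lower number a stronger inhibitor), compound 1 reaches only a limit of the assay, > 200000 nM.
Compound 2 `C#CCSc1nnc(CCC)n1N1C(=O)c2ccccc2C1=O` — compound 2 likewise gives a limit, > 200000 nM.
Compound 3 `C#CCSc1nnc(-c2cc(OC)c(OC)c(OC)c2)n1N1C(=O)c2ccccc2C1=O` — compound 3 also gives a limit, > 200000 nM.

Compound 2 and compound 1 differ by (4-chlorophenyl)carbonyl in place of ethynyl on a saturated chain carbon bound to a sulfur. The step that the two limits leave unreadable from compound 2 to compound 1 cannot be read because of the limit of > 200000 nM in this assay, at which 3 of the 3 values shown sit. The core of compound 3 differs from that of compound 2 in more than one place; that difference is not broken down here. Compound 4 `COc1cc(-c2nnc(SCC(=O)c3ccc(Cl)cc3)n2N2C(=O)c3ccccc3C2=O)cc(OC)c1OC` differs from compound 3 by (4-chlorophenyl)carbonyl in place of ethynyl on a saturated chain carbon bound to a sulfur, the same change as from compound 2 to compound 1. Since both partners of the earlier pair sit at the limit of > 200000 nM in this assay, at which 3 of the 3 values shown sit, the change has shown no readable effect. Compound 4 is therefore expected at 400000 nM, most likely again as a limit. The expected step that the limit leaves unreadable from compound 3 to compound 4 is estimated as essentially flat.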

Compound 4, half-maximal inhibitory concentration: 22000 nM
Compound 4: middle estimate off by 18-fold (1.26 log units), on the high side; measured number below the stated range.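

In this assay, (4-chlorophenyl)carbonyl in place of ethynyl on a saturated chain carbon bound to a sulfur gives an at least 9.0-fold lower number from compound 3 to compound 4 (0.95 log units; beyond the scatter) on the core bearing 3,4,5-trimethoxyphenyl, and with that side chain held fixed, 3,4,5-trimethoxyphenyl in place of propyl gives an at least 9.0-fold lower number from compound 1 to compound 4 (0.95 log units; beyond the scatter). The same change on the core bearing propyl cannot be read, nor can the other steps among the remaining compounds, because their values are limits: the limit of > 200000 nM in this assay, at which 3 of the 4 values shown sit. Compound 4 alone gives a number rather than a limit, so the change is shown to act on one core, but neither its transfer to another core nor its failure to transfer is shown.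

The compounds shown leave open how much of the step belongs to the chlorine of the (4-chlorophenyl)carbonyl group. They also leave open whether a plain phenyl or a carboxylic acid in place of 3,4,5-trimethoxyphenyl would give a readable number.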